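The source may hold more compounds than are shown below. What is called first, only, known or untested is meant among the compounds shown, and "the series" means these compounds.

Series notes. Compound 1 `Cc1ccc(-c2nnc(SCCCN3CCN(c4cccc(Cl)c4)CC3)[nH]2)cc1` and compound 2 `Clc1ccc(-c2nnc(SCCCN3CCN(c4cccc(Cl)c4)CC3)[nH]2)cc1` share one core; compound 3 `Cc1ccc(-c2nn(CCCN3CCN(c4cccc(Cl)c4)CC3)c(=S)[nH]2)cc1` and compound 4 `S=c1[nH]c(-c2ccc(Cl)cc2)nn1CCCN1CCN(c2cccc(Cl)c2)CC1` share another. The difference between the two cores is not broken down here. In a functional assay on COLO 205 cells (Homo sapiens) for cytotoxicity, read by MTT assay, with a stated time of 24 h (on this read-out higher numbers stand for weaker inhibition and lower numbers for stronger inhibition), compound 1 gives 139000 nM. Compound 2 gives only a limit, > 300000 nM. Compound 3 likewise gives only a limit, > 300000 nM. The change from compound 1 to compound 2 is chloro in place of methyl on an aromatic carbon, and it gave an at least 2.1-fold higher number from compound 1 to compound 2 (0.33 log units; beyond the scatter). The change from compound 3 to compound 4 is chloro in place of methyl on an aromatic carbon, the same change on the other core. Compound 3 already sits at the limit of > 300000 nM in this assay, at which 2 of the 3 values shown sit, so the change is expected to leave compound 4 at the limit as well, with a step that the limit leaves unreadable from compound 3 to compound 4 as the estimated step. For compound 4 in this assay the estimate is 500000 nM, between 250000 nM and 1500000 nM.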

Compound 4, half-maximal inhibitory concentration: > 300000 nM
Compound 4 gave a limit, no number; the forecaster's own chance of this, stated with the estimate: 85%; the middle value lies beyond the limit too.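

Compound 3 and compound 4 both give only limits in this assay, so no step can be read between them: the limit of > 300000 nM in this assay, at which 3 of the 4 values shown sit.

The compounds shown leave open what chloro in place of methyl does on the core of compound 3.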